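Shrinking the piperazine aryl group: from oxadiazole to pyrimidine

A few compounds are considered here, and "the series" means these few. Any claim that something is new, unique, unknown or untested is made for them only; others in the source may bear on it.

Compound 1 `CC#CCn1c(N2CCC[C@@H](N)C2)nc2c1c(=O)n(CCCN1CCC(c3ncc(-c4ccccc4)o3)CC1)c(=O)n2C` gives 830 nM in a functional assay on HEK293 cells for agonist activity at Glucose-dependent insulinotropic receptor (Homo sapiens), read by a luciferase reporter; on this read-out lower numbers stand for an effect already at smaller amounts and higher numbers for an effect only at larger amounts of compound.
Compound 2 `CC#CCn1c(N2CCC[C@@H](N)C2)nc2c1c(=O)n(CCCN1CCC(c3nc(-c4ccccc4)cs3)CC1)c(=O)n2C` gives 3130 nM in this assay.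
Compound 3 `CC#CCn1c(N2CCC[C@@H](N)C2)nc2c1c(=O)n(CCCN1CCN(c3noc(-c4ccccc4)n3)CC1)c(=O)n2C` gives 1450 nM in this assay.

Among these three, compound 3 sits in the middle. Compound 3 and compound 1 lie within the scatter of each other, so no order between them can be read. Compound 2, with its number beyond the scatter from compound 3, needs more compound than compound 3 does.

The new compound is compound 4 `CC#CCn1c(N2CCC[C@@H](N)C2)nc2c1c(=O)n(CCCN1CCN(c3ncc(C)cn3)CC1)c(=O)n2C`. The change is 5-methylpyrimidin-2-yl in place of 5-phenyl-1,2,4-oxadiazol-3-yl on an amine nitrogen in a ring. Among the measured compounds shown here, only one measured step exists, a 3.8-fold higher number from compound 1 to compound 2 (0.58 log units; beyond the scatter), and it concerns a swap of one phenyl-bearing five-membered ring for another on a ring carbon, not the loss of a phenyl ring from a ring nitrogen. It shows that exchanging the aryl group at this end of the molecule can move the number by a modest amount. For the measured compounds named here, no measured step shows what removing the phenyl ring does.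

Given this, compound 4 is expected to show a 1.7-fold higher number from compound 3 to compound 4 (0.24 log units; within the scatter), a small weakening with wide uncertainty. The estimate for compound 4 is 2500 nM, with a range from 700 nM to 9000 nM.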

Compound 4, half-maximal effective concentration: 2560 nM
Estimate against measurement, compound 4: 1.0-fold (0.01 log units) below; low and high end bracket the measured number.
By their numbers in this assay, from the lowest: compounds 1, 3, 4 and 2 (each within the scatter of the next, the first and the last beyond it).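

On the amine nitrogen of the six-membered ring with 2 nitrogen, 5-methylpyrimidin-2-yl in place of 5-phenyl-1,2,4-oxadiazol-3-yl gives a 1.8-fold higher number from compound 3 to compound 4 (0.25 log units; within the scatter) in this assay, so the two compounds cannot be told apart on this read-out. Among the compounds shown here, this is the first sign that a much smaller group can sit here: the entering group has 7 heavy atoms and one aromatic ring, while the leaving group has 11 heavy atoms and two aromatic rings. Nothing measured here offers an explanation for this result.

Open, on these data alone, is what the methyl on the pyrimidine contributes, since a pyrimidin-2-yl group without it would be needed to show that. Also open, as far as these compounds go, is how a group of another kind at this nitrogen, such as an amine or a carboxylic acid, would read.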